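Side-chain variation at the amide carbon: compound 3

This account rests on a few compounds, and the source may have more. Where it says the series, first, only, none or still open, it means among the compounds named here.

Measured so far:
compound 1 `O=C(CN(c1nc(Cl)nc2[nH]cnc12)C1CC1)N[C@@H](CC(=O)OCc1ccccc1)C(=O)OCc1ccccc1`: 12.1%
compound 2 `CC[C@H](C)[C@H](NC(=O)CN(c1nc(Cl)nc2[nH]cnc12)C1CC1)C(=O)OCc1ccccc1`: 22%

In a functional assay on the whole organism (Tail, strain ICR) with Mus musculus as the target, in the tail flick test, with a stated time of 120 min, at a dose of 25 umol/kg by the oral route (a lower number here means a weaker effect, a higher number a stronger effect of the compound at the dose given), compound 2 stands within the scatter of compound 1; the two numbers do not separate. Among the compounds with values here, the only measured step at this position, a number 9.9 percentage points higher from compound 1 to compound 2 (within the scatter), exchanged a larger side chain and stayed within the scatter. Compound 3 `CC(C)C[C@H](NC(=O)CN(c1nc(Cl)nc2[nH]cnc12)C1CC1)C(=O)OCc1ccccc1` differs from compound 2 by isobutyl in place of sec-butyl on a saturated chain carbon bound to an amide-type nitrogen and a carbonyl carbon. Within the data shown here, with one flat step of this kind as the only guide, no step beyond the scatter is expected, so compound 3 is estimated at 22% (range 8% to 36%), a step of no change at the digits printed from compound 2 to compound 3 (within the scatter).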

Compound 3, a percentage reported as activity, at one dose (the size of the read-out at that dose, not a potency): 8.58%
The estimate for compound 3 lay 13.4 percentage points above the measured number, within the range that was stated.
By their numbers in this assay, from the lowest: compounds 3, 1 and 2 (each within the scatter of the next, the first and the last beyond it).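

In this assay, within the data shown here, the exchange of sec-butyl for isobutyl, two groups with the same atoms, gives a number 13.4 percentage points lower from compound 2 to compound 3 (beyond the scatter) and is the first step beyond the scatter at this position; the side chain's arrangement therefore matters here, not only its atom count. Benzyloxycarbonyl replaced by isopropyl gives a number 3.5 percentage points lower from compound 1 to compound 3 (within the scatter) and does not separate the two compounds. No evidence is available to explain the drop. Open, on these data alone, is how a side chain bearing an amine, a carboxylic acid or a longer unbranched chain would read at this position.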